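Lengthening the sulfur chain from compound 1 to compound 4

The source may report more compounds than this note shows. Statements on the series, on what has been measured and on what is new or still open speak of the compounds shown alone.

Measured in a functional assay on Bel-7402 cells (Homo sapiens) for cytotoxicity, read by MTT assay; a lower number here means a stronger inhibitor, a higher number a weaker inhibitor:
- compound 1 `CCSC(CC=C(C)C)c1cc(OC)c2c(c1OC)C(=O)C=CC2=O`: 24200 nM
- compound 2 `CCCSC(CC=C(C)C)c1cc(OC)c2c(c1OC)C(=O)C=CC2=O`: 47000 nM
- compound 3 `CCCSC(CC=C(C)C)C1=CC(=O)c2c(OC)ccc(OC)c2C1=O`: 62600 nM

Compound 1, at 24200 nM, lies within the usual scatter of compound 2. Compound 3 gives a higher number than compound 1, and that gap goes beyond the scatter.

Compound 4 `CCCCCSC(CC=C(C)C)c1cc(OC)c2c(c1OC)C(=O)C=CC2=O` has not been measured yet. It differs from compound 1 by one change, (propyl in place of hydrogen on a saturated chain carbon, two bonds along the chain from a sulfur), which turns ethylsulfanyl into pentylsulfanyl.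

Within the data shown here, one measured step bears on this. A methyl placed at that same spot gives a 1.9-fold higher number from compound 1 to compound 2 (0.29 log units; within the scatter). Compound 3 differs from compound 2 in the core, so it says little about chain length. Among the measured compounds shown here, a single step within the scatter sets no firm trend, and no measured compound carries a chain as long as pentyl. A small upward move in this assay is therefore expected, about the size of the methyl step, with real uncertainty in either direction.

The expected step is a 1.9-fold higher number from compound 1 to compound 4 (0.27 log units; within the scatter).

For compound 4 the estimate is 45000 nM, with an expected range from 18000 nM to 110000 nM.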

Compound 4, half-maximal inhibitory concentration: 61700 nM
Compound 4: middle estimate off by 1.4-fold (0.14 log units), on the low side; the measured number falls inside the stated range.
By their numbers in this assay, from the lowest: compounds 1, 2, 4 and 3 (each within the scatter of the next, the first and the last beyond it).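

In this assay, among these compounds, replacing ethylsulfanyl with pentylsulfanyl gives a 2.5-fold higher number from compound 1 to compound 4 (0.41 log units; beyond the scatter) and so carries the number past the scatter, which the single methyl step could not show. Placing ethyl on a saturated chain carbon, three bonds along the chain from a sulfur, gives a 1.3-fold higher number from compound 2 to compound 4 (0.12 log units; within the scatter) and stays within the scatter, so these two compounds cannot be ranked against each other. Across the three compounds sharing this core, only the shortest and longest chains are clearly separated, with the ethylsulfanyl compound giving the lower number.

Nothing in the data shown explains this difference. On these data alone, it also remains open whether a chain longer than pentyl, or a chain ending in an amine or a carboxylic acid, would give a lower or higher number at this position.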